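A few compounds are considered here, and "the series" means these few. Any claim that something is new, unique, unknown or untested is made for them only; others in the source may bear on it.

Measured so far:
Compound 1 `CCn1ccc2cc(NC(=O)CN(c3cc(Cl)ccc3OC)S(=O)(=O)c3ccccc3)ccc21` in a functional assay on SH-SY5Y cells (Homo sapiens), read by MTT assay, with a stated time of 24 h (on this read-out lower numbers stand for an effect already at smaller amounts and higher numbers for an effect only at larger amounts of compound), gives 2220 nM.
Compound 2 `COc1ccc(CNC(=O)CN(c2cc(Cl)ccc2OC)S(=O)(=O)c2ccccc2)cc1` gives > 20000 nM, which is a limit of the assay and not a number.

Compound 2 thus sits at the limit of > 20000 nM in this assay, at which 1 of the 2 values shown sits, in this assay. Compound 3 `COc1ccc(Cl)cc1N(CC(=O)Nc1ccc([N+](=O)[O-])cc1)S(=O)(=O)c1ccccc1` differs from it by 4-nitrophenyl in place of 4-methoxybenzyl on an amide-type nitrogen. Within the data shown here, one measured step bears on this change: an at least 9.0-fold higher number from compound 1 to compound 2 (0.95 log units; beyond the scatter), in which an aromatic ring carried on that nitrogen gave way to a benzyl group. Compound 3 again carries an aromatic ring on that nitrogen, as compound 1 does, so a step to a lower number is expected, an at least 4.0-fold lower number from compound 2 to compound 3 (0.60 log units; beyond the scatter). Compound 3 is estimated at 5000 nM, within 1500 nM to 20000 nM.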

Compound 3, half-maximal effective concentration: 8210 nM
For compound 3 the middle estimate is 1.6-fold (0.22 log units) below the measured one, and the stated range covers the measured number.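

In this assay, 4-nitrophenyl on the amide-type nitrogen gives an at least 2.4-fold lower number from compound 2 to compound 3 (0.38 log units; beyond the scatter), so among these compounds a measurable value goes with an aromatic ring carried directly on that nitrogen. Compound 2 stands at a limit of the assay, not at a number: the limit of > 20000 nM in this assay, at which 1 of the 3 values shown sits. Such a ring does not settle the value by itself, as 1-ethyl-1H-indol-5-yl gives way to 4-nitrophenyl with a 3.7-fold higher number from compound 1 to compound 3 (0.57 log units; beyond the scatter).

Going by these compounds, it remains open whether the nitro group matters or whether any aromatic ring there would serve. An unsubstituted phenyl or a 4-methoxyphenyl on that nitrogen would separate the two.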